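A few compounds are considered here, and "the series" means these few. Any claim that something is new, unique, unknown or untested is made for them only; others in the source may bear on it.

Compound 3 `O=C1NC(=O)C(Cc2ccc(OCC3CCC3)cc2)S1` gives > 100000 nM in a functional assay on PC-12 cells (Rattus norvegicus) for inhibition, read by sulforhodamine B assay (on this read-out lower numbers stand for stronger inhibition and higher numbers for weaker inhibition), which is a limit and not a number. Compound 1 `O=C1NC(=O)C(Cc2ccc(OCC3CCCCO3)cc2)S1` gives > 100000 nM, also a limit. Going by the values given here, compound 2 `O=C1N=C(O)S/C1=C\c1ccc(OCC2CCCCO2)cc1` gives 22000 nM, the only true number so far. Compound 3 therefore stands at the limit of > 100000 nM in this assay, at which 2 of the 3 values shown sit.

Compound 4 `CC(C)COc1ccc(CC2SC(=O)NC2=O)cc1` carries isopropyl in place of cyclobutyl on a saturated chain carbon bound to an oxygen on an aromatic ring. Among the compounds with values here, the one measured step at this place is a step that the two limits leave unreadable from compound 1 to compound 3, so it offers no size to carry over. No step beyond the scatter is expected in this assay. The expected change is a number no higher from compound 3 to compound 4 (the limit leaves the size open). Compound 4 is estimated at 100000 nM, with an expected range of 40000 nM to 200000 nM.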

Compound 4, half-maximal inhibitory concentration: 25000 nM
Estimate against measurement, compound 4: 4.0-fold (0.60 log units) above, and the stated range ends above it.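

In this assay, the place on a saturated chain carbon bound to an oxygen on an aromatic ring now gives readable steps: isopropyl in place of cyclobutyl gives an at least 4.0-fold lower number from compound 3 to compound 4 (0.60 log units; beyond the scatter). Isopropyl in place of oxan-2-yl gives an at least 4.0-fold lower number from compound 1 to compound 4 (0.60 log units; beyond the scatter). Both steps start from a limit and not a number, so their full size stays open: the limit of > 100000 nM in this assay, at which 2 of the 4 values shown sit.

Still open, as far as these compounds go, is how a longer straight chain or an amine at this place would read. Also open, from the compounds shown here alone, is whether isopropyl would carry the same step on the core of compound 2.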